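This account rests on a few compounds, and the source may have more. Where it says the series, first, only, none or still open, it means among the compounds named here.

Measured compounds:
compound 1, `O=c1cc(-n2cc(CNc3ccccc3)nn2)c2cc(Br)ccc2o1`, 13200 nM
compound 2, `O=c1cc(-n2cc(COc3cccnc3)nn2)c2cc(Br)ccc2o1`, 24800 nM
compound 3, `COC(=O)c1ccccc1OCc1cn(-c2cc(=O)oc3ccc(Br)cc23)nn1`, 5250 nM

In a functional assay on A549 cells (Homo sapiens) for antiproliferative activity, read by MTT assay, with a stated time of 48 h (on this read-out lower numbers stand for stronger inhibition and higher numbers for weaker inhibition), compound 3 gives the lowest of the three numbers; compound 1 is nearest to it and compound 2 furthest, and both of those gaps lie beyond the usual scatter. Compound 4, `O=c1cc(-n2cc(COc3ccccc3Br)nn2)c2cc(Br)ccc2o1`, differs from compound 3 by bromo in place of methoxycarbonyl on an aromatic carbon. Among the compounds with values here, only one measured step exists, a 1.9-fold higher number from compound 1 to compound 2 (0.27 log units; within the scatter), and it changes a different part of the shared core, so it does not bear on this exchange. Lacking a comparable step, no shift beyond the scatter is expected in this assay in either direction. Compound 4 is therefore estimated at 6000 nM, with a range from 2500 nM to 15000 nM. The expected step is a 1.1-fold higher number from compound 3 to compound 4 (0.06 log units; within the scatter).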

Compound 4, half-maximal inhibitory concentration: 8430 nM
Beside the measured number, compound 4's estimate is 1.4-fold (0.15 log units) below it; measured number inside the range.
By their numbers in this assay, from the lowest: compounds 3, 4, 1 and 2 (each within the scatter of the next, the first and the last beyond it).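

Exchanging methoxycarbonyl for bromo on this aromatic carbon in this assay leaves the two compounds within the scatter of each other (a 1.6-fold higher number from compound 3 to compound 4 (0.21 log units; within the scatter)), so a single bromine atom serves here about as well as the larger ester. Against the pyridin-3-yl ether, the 2-bromophenyl group gives a modest gain beyond the scatter (a 2.9-fold lower number from compound 2 to compound 4 (0.47 log units; beyond the scatter)). Against the anilino compound, 2-bromophenoxy stays within the scatter (a 1.6-fold lower number from compound 1 to compound 4 (0.19 log units; within the scatter)). As far as these compounds go, whether a carboxylic acid or an amine on this carbon would hold the same level remains open. No measured evidence accounts for these results.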